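The source may report more compounds than this note shows. Statements on the series, on what has been measured and on what is new or still open speak of the compounds shown alone.

Measured compounds:
Compound 1, `COCc1c(C)coc1-c1ccc2c(c1OC)CCCC2(C)C`, gives 17.5 uM.
Compound 2, `CCOc1c(-c2occ(C)c2CO)ccc2c1CCCC2(C)C`, gives 17.5 uM.
Compound 3, `Cc1coc(-c2ccc3c(c2O)CCCC3(C)C)c1CO`, gives 22.7 uM.

In a functional assay on DU-145 cells (Homo sapiens) for cytotoxicity, read by sulforhodamine B assay, with a stated time of 3 days (a lower number here means that less compound is needed, a higher number that more compound is needed for the effect), the three measured compounds lie close together. Among the measured compounds shown here, compound 1 stands level with compound 2 at the digits given, and together they hold the lowest of the three numbers; compound 3 stands a little higher, but the only single-place step that connects two measured compounds, a 1.3-fold higher number from compound 2 to compound 3 (0.11 log units; within the scatter), is within the scatter, so no order can be read from these three.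

Compound 4, `COC(=O)c1c(C)coc1-c1ccc2c(c1OC)CCCC2(C)C`, differs from compound 1 in one place: methoxycarbonyl in place of methoxymethyl on an aromatic carbon. For the measured compounds named here, none of the measured steps touches this position; the one available step, on an oxygen of the six-membered aromatic ring, tells nothing about a change on the five-membered ring. What the data do show is that every change so far has left this assay unmoved, so compound 4 is expected to sit with the others, and a 1.1-fold higher number from compound 1 to compound 4 (0.06 log units; within the scatter) is expected to be a step that does not rise beyond the scatter. For compound 4 the estimate is 20 uM, with a range from 8 uM to 50 uM.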

Compound 4, concentration for half-maximal effect: 33.5 uM
Beside the measured number, compound 4's estimate is 1.7-fold (0.22 log units) below it; the range from low to high includes it.
By their numbers in this assay, from the lowest: compounds 1, 2, 3 and 4 (each within the scatter of the next).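

Among the compounds shown here, this is the first measured step at this position, the aromatic carbon of the five-membered aromatic ring that carries methoxymethyl in compound 1, and in this assay methoxycarbonyl in place of methoxymethyl gives a 1.9-fold higher number from compound 1 to compound 4 (0.28 log units; within the scatter). At this position, then, a group with a double bond outside the aromatic rings and one without are not told apart in this read-out, although both the heavy atoms and the hydrogen-bond acceptors of the group differ between them. Nothing available bears on why the number stays within the scatter for this change.

On these data alone, both groups compared here are uncharged and have no hydrogen-bond donors, so it remains open whether an amine, a carboxylic acid or a longer chain at this position would give a step beyond the scatter. Also open, as far as these compounds go, is whether the same exchange would give a similar step on the core of compound 3, where a hydrogen stands on the oxygen of the other aromatic ring, since this position has been compared only on the core of compound 1.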